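Adding a Methoxy Group to Compound 2

A few compounds are considered here, and "the series" means these few. Any claim that something is new, unique, unknown or untested is made for them only; others in the source may bear on it.

Two compounds measured in an in vitro assay on cells for inhibition of Amine oxidase [flavin-containing] B (Homo sapiens), read by fluorescence and Amplex Red, with stated times of 30 min and 45 min (on this read-out higher numbers stand for weaker inhibition and lower numbers for stronger inhibition), set the scene. Compound 1 `O=C(CCCc1ccccc1)Nc1nc2ccsc2c(=O)s1` gives 206 nM in this assay, while compound 2 `O=C(CCc1ccccc1)Nc1nc2ccccc2c(=O)s1` gives 17.6 nM. Compound 2 therefore stands lowest of the two numbers, and compound 1, its nearest neighbour, lies higher by a margin beyond the usual scatter. Going by the values given here, compound 1 and compound 2 differ in more than one place, so no single step is counted between them. Compound 3 `COc1cccc(CCC(=O)Nc2nc3ccccc3c(=O)s2)c1` is the unmeasured partner of compound 2. The difference between them is methoxy in place of hydrogen on an aromatic carbon. Among the compounds with values here, nothing among the measured compounds shows the effect of such a change on its own, so the expected step is a 1.3-fold higher number from compound 2 to compound 3 (0.10 log units; within the scatter), a small one that may go either way and is likely to stay within the scatter. Compound 3 is accordingly estimated at 22 nM, with a range from 8 nM to 65 nM.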

Compound 3, half-maximal inhibitory concentration: 95.3 nM
For compound 3 the middle estimate is 4.3-fold (0.64 log units) below the measured one, and the stated range ends below it.
By their numbers in this assay, from the lowest: compound 2; then compound 3; then compound 1.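

In this assay, going from phenyl to 3-methoxyphenyl gives a 5.4-fold higher number from compound 2 to compound 3 (0.73 log units; beyond the scatter), so this carbon of the aromatic ring does not take a methoxy group without a loss of inhibition. This pair is the first among the compounds shown to differ in one place only, which makes it the first direct reading of what a change on this ring does to the number. Nothing measured here gives a reason for the rise.

Still open, as far as these compounds go, is whether a fluorine or a hydroxyl on the same carbon would cost as much as methoxy does, or whether methoxy on another carbon of the ring would do the same. Also open, from the compounds shown here alone, is whether a methoxy group would have a similar effect on the longer chain and different core of compound 1.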